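This account rests on a few compounds, and the source may have more. Where it says the series, first, only, none or still open, it means among the compounds named here.

Measured compounds:

Compound 1 `COc1cc(-c2nn(-c3cccc(NC(=O)Nc4cc(C(F)(F)F)cc(C(F)(F)F)c4)c3)cc2-c2ccncc2)ccc1Cl` — in a functional assay on RPMI-8226 cells (Homo sapiens) for inhibition, read by sulforhodamine B assay, with a stated time of 48 h (a lower number here means a stronger inhibitor of growth, a higher number a weaker inhibitor of growth), compound 1 gives > 50000 nM, which is a limit of the assay and not a number.
Compound 2 `O=C(Nc1cccc(-n2cc(-c3ccncc3)c(-c3ccc(Cl)c(O)c3)n2)c1)Nc1cc(C(F)(F)F)cc(C(F)(F)F)c1` — in this assay compound 2 gives > 50000 nM, again a limit of the assay and not a number.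
Among the compounds with values here, compound 3 `COc1cc(-c2nn(-c3cccc(NC(=O)Nc4ccc(Cl)c(C(F)(F)F)c4)c3)cc2-c2ccncc2)ccc1Cl` — in this assay compound 3 gives 3250 nM, the only number among the three.

Compound 1 and compound 2 share a core and differ only by hydrogen in place of methyl on an oxygen on an aromatic ring. Both values sit at the limit of > 50000 nM in this assay, at which 2 of the 3 values shown sit, so the step that the two limits leave unreadable from compound 1 to compound 2 cannot be sized in either direction.

Compound 3 carries a different urea end; the difference between the core of compound 3 and the core of compound 1 is not broken down here. Compound 4 `O=C(Nc1cccc(-n2cc(-c3ccncc3)c(-c3ccc(Cl)c(O)c3)n2)c1)Nc1ccc(Cl)c(C(F)(F)F)c1` has not yet been measured in this assay. It is reached from compound 3 by hydrogen in place of methyl on an oxygen on an aromatic ring, the same change that takes compound 1 to compound 2, at the same place and with the same surroundings.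

Since the step from compound 1 to compound 2 left no readable size, the expectation for compound 4 rests on compound 3 alone, whose value 3250 nM is the only anchor. For compound 4 the step of a 1.5-fold higher number from compound 3 to compound 4 (0.19 log units; within the scatter) is estimated as small and not decisive in either direction. Compound 4 is expected to give about 5000 nM in this assay, with a plausible range from 2000 nM to 20000 nM, and a real chance that the assay returns only a limit.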

Compound 4, concentration for total growth inhibition: 2000 nM
Estimate against measurement, compound 4: 2.5-fold (0.40 log units) above, and the stated range covers the measured number.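

Going from methoxy to hydroxy on the aromatic ring gives, in this assay, a 1.6-fold lower number from compound 3 to compound 4 (0.21 log units; within the scatter), so on this core the two groups cannot be told apart. On the core of compound 1, the same change cannot be read, as compound 1 and compound 2 both stand at a limit of the assay and neither gives a number: the limit of > 50000 nM in this assay, at which 2 of the 4 values shown sit.

Carrying the change from one core to the other therefore rests on a single readable pair: it shows that the hydroxy compound gives a number on the core of compound 3, but it does not show whether the change acts alike or differently on the two cores.

Still open, going by these compounds, is whether another group at this place on the aromatic ring, such as an amine, a carboxylic acid or a longer chain like ethoxy, would stand apart from compound 4 at 2000 nM. Also open is whether a urea end other than the two shown, for instance one carrying a nitrile, would give a second readable pair for the methoxy to hydroxy change.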